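This account rests on a few compounds, and the source may have more. Where it says the series, first, only, none or still open, it means among the compounds named here.

Measured compounds:
compound 1, `Cc1ccc2nc([C@H](CC3CCN(C(=O)C(C)C)CC3)N3C(=O)CN(c4ccc(Oc5ccccc5)cc4)C3=O)n(C)c2c1`, 35 nM
compound 2, `CC(C)C(=O)N1CCC(C[C@@H](c2nc3cc(F)ccc3n2C)N2C(=O)CN(c3ccc(Oc4ccccc4)cc3)C2=O)CC1`, 340 nM

Among the measured compounds shown here, in an assay on isolated protein for antagonist activity at Bile acid receptor (Homo sapiens), read by TR-FRET and LanthaScreen (on this read-out higher numbers stand for weaker inhibition and lower numbers for stronger inhibition), compound 2 gives 340 nM, the higher of the two numbers so far; the only neighbour is compound 1 with 35 nM, and the step of a 9.7-fold higher number from compound 1 to compound 2 (0.99 log units; beyond the scatter) is beyond the scatter. Compound 3, `CC(C)C(=O)N1CCC(C[C@@H](c2nc3ccc(Cl)cc3n2C)N2C(=O)CN(c3ccc(Oc4ccccc4)cc3)C2=O)CC1`, has not been measured. It differs from compound 2 in one place: 6-chloro-1-methyl-1H-benzimidazol-2-yl in place of 5-fluoro-1-methyl-1H-benzimidazol-2-yl on a saturated chain carbon bound to an amide-type nitrogen in a ring and a saturated chain carbon. A single measured step bears on this change, a 9.7-fold higher number from compound 1 to compound 2 (0.99 log units; beyond the scatter), in which the 1,6-dimethyl group gave way to the 5-fluoro group and the number rose well beyond the scatter. The group entering compound 3 again carries its second substituent as a 6-substituent, as the group of compound 1 does, though with a chlorine rather than a methyl, so a partial return toward the number of compound 1 seems plausible rather than certain. Compound 3 is therefore expected near 100 nM, with a range from 30 nM to 350 nM, an estimated step of a 3.4-fold lower number from compound 2 to compound 3 (0.53 log units; beyond the scatter).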

Compound 3, half-maximal inhibitory concentration: 130 nM
Estimate against measurement, compound 3: 1.3-fold (0.11 log units) below, and the stated range covers the measured number.
By their numbers in this assay, from the lowest: compound 1; then compound 3; then compound 2.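

In this assay, 6-chloro-1-methyl-1H-benzimidazol-2-yl in place of 5-fluoro-1-methyl-1H-benzimidazol-2-yl gives a 2.6-fold lower number from compound 2 to compound 3 (0.42 log units; beyond the scatter), so a second exchange at this position on the saturated chain carbon moves the number beyond the scatter, and this time downward. Chloro in place of methyl on an aromatic carbon gives a 3.7-fold higher number from compound 1 to compound 3 (0.57 log units; beyond the scatter), which shows that the name of the substituent matters as well as where it sits: the two groups carrying a 6-substituent do not give matching numbers, and compound 1 keeps the lowest number of the three. The data hold no measurement that accounts for either step.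

The step from compound 2 to compound 3 changes the halogen and its ring position together, so these two contributions stay unseparated without the 6-fluoro-1-methyl-1H-benzimidazol-2-yl or 5-chloro-1-methyl-1H-benzimidazol-2-yl group. With only methyl and chloro shown as 6-substituents, the compounds also leave open how a larger or differently built group there, such as methoxy, nitrile or trifluoromethyl, would compare with the methyl of compound 1.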